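A few compounds are considered here, and "the series" means these few. Any claim that something is new, unique, unknown or untested is made for them only; others in the source may bear on it.

Values so far in a functional assay (aorta) with Rattus norvegicus as the target; on this read-out higher numbers stand for weaker inhibition and lower numbers for stronger inhibition:
compound 1 `CC(C)c1cn2ccccc2c1S(=O)(=O)c1ccc(OCCCNCc2ccccc2)cc1`: 22.8 nM
compound 2 `CCCCCN(CCCCC)CCCOc1ccc(S(=O)(=O)c2c(C(C)C)cn3ccccc23)cc1`: 89.6 nM
compound 3 `COc1ccc(CNCCCOc2ccc(S(=O)(=O)c3c(C(C)C)cn4ccccc34)cc2)cc1OC`: 13 nM

Compound 3 stands level with compound 1 at the low end of these numbers, with a 1.8-fold lower number from compound 1 to compound 3 (0.24 log units; within the scatter) as the step between them. It stands clear of compound 2, with a 6.9-fold lower number from compound 2 to compound 3 (0.84 log units; beyond the scatter) separating the pair.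

The next compound, compound 4 `COc1ccc(NCCCOc2ccc(S(=O)(=O)c3c(C(C)C)cn4ccccc34)cc2)cc1OC`, changes one place, on an amine nitrogen: 3,4-dimethoxyphenyl in place of 3,4-dimethoxybenzyl on an amine nitrogen puts 3,4-dimethoxyphenyl in place of 3,4-dimethoxybenzyl.

Going by the values given here, no measured step makes this exact change. The nearest evidence is a 3.9-fold higher number from compound 1 to compound 2 (0.59 log units; beyond the scatter) together with a 6.9-fold lower number from compound 2 to compound 3 (0.84 log units; beyond the scatter), both modest steps at this same amine, while the change on the ring in a 1.8-fold lower number from compound 1 to compound 3 (0.24 log units; within the scatter) stays within the scatter. The only measured departure from a benzyl-type group, in compound 2, raised the number, so a modest rise is expected, though the direction is uncertain.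

The expected change is a 2.7-fold higher number from compound 3 to compound 4 (0.43 log units; beyond the scatter) by estimate. For compound 4 the estimate is 35 nM, with an expected range from 10 nM to 120 nM in that assay.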

Compound 4, half-maximal inhibitory concentration: 396 nM
Beside the measured number, compound 4's estimate is 11-fold (1.05 log units) below it; the measured number lies above the stated range.
By their numbers in this assay, from the lowest: compounds 3 and 1 (each within the scatter of the next); then compound 2; then compound 4.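

In this assay, putting 3,4-dimethoxyphenyl in place of 3,4-dimethoxybenzyl on the amine nitrogen gives a 30-fold higher number from compound 3 to compound 4 (1.48 log units; beyond the scatter), and the comparison with benzyl gives a 17-fold higher number from compound 1 to compound 4 (1.24 log units; beyond the scatter), whereas the ring change alone gave only a 1.8-fold lower number from compound 1 to compound 3 (0.24 log units; within the scatter); at this position, the link between the ring and the amine nitrogen therefore counts for far more than the methoxy groups on the ring. An aromatic ring on this nitrogen does not by itself keep the number low, since the dialkyl amine compares favourably, with a 4.4-fold higher number from compound 2 to compound 4 (0.65 log units; beyond the scatter). Nothing available here accounts for the size of this rise.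

The compounds shown leave open whether an unsubstituted phenyl on the amine nitrogen would behave like compound 4. They also leave open whether a phenethyl group, with its longer link, would behave like the benzyl compounds.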